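Ethynyl for Phenyl: Leaving the Limit?

This account rests on a few compounds, and the source may have more. Where it says the series, first, only, none or still open, it means among the compounds named here.

Measured in a functional assay on K562 cells (Homo sapiens), read by MTT assay, with a stated time of 72 h (on this read-out lower numbers stand for stronger inhibition and higher numbers for weaker inhibition), all three values being limits:
- compound 1 `CSc1ncnc2c1c(-c1cccs1)cn2[C@@H]1O[C@H](CO)[C@@H](O)[C@H]1O`: > 20000 nM
- compound 2 `CSc1ncnc2c1c(-c1ccsc1)cn2[C@@H]1O[C@H](CO)[C@@H](O)[C@H]1O`: > 20000 nM
- compound 3 `CSc1ncnc2c1c(-c1ccccc1)cn2[C@@H]1O[C@H](CO)[C@@H](O)[C@H]1O`: > 20000 nM

Compound 3 carries a phenyl group and stands at a limit, not at a number: > 20000 nM. The whole set sits at the limit of > 20000 nM in this assay, at which 3 of the 3 values shown sit, so no order among the three compounds can be read.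

The next compound, compound 4 `C#Cc1cn([C@@H]2O[C@H](CO)[C@@H](O)[C@H]2O)c2ncnc(SC)c12`, keeps the shared core and changes one group: ethynyl in place of phenyl on an aromatic carbon. All three measured compounds carry an aromatic ring at this carbon, whereas the ethynyl group of compound 4 has no ring.

Only the swaps among those aromatic groups bear on this change, and they say little about its size. For the measured compounds named here, the first swap gave a step that the two limits leave unreadable from compound 1 to compound 3. The second gave a step that the two limits leave unreadable from compound 2 to compound 3. The third gave a step that the two limits leave unreadable from compound 1 to compound 2. None of them tests a group without a ring, so the data do not fix the size of this step.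

Compound 4 may well stay at the limit, and any readable step is expected toward stronger inhibition in this assay. The expected size is an at least 1.3-fold lower number from compound 3 to compound 4 (0.12 log units; that floor lies within the scatter). For compound 4 the estimated value is 15000 nM, with an expected range from 2000 nM to 40000 nM.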

Compound 4, half-maximal inhibitory concentration: 70 nM
For compound 4 the middle estimate is 210-fold (2.33 log units) above the measured one; measured number outside the range, below it.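

This carbon is not closed to activity: in this assay the position two ring bonds from the ring nitrogen gives a readable number once the aromatic ring on it is replaced by ethynyl. The change is large against each ring-bearing compound, with ethynyl in place of phenyl giving an at least 280-fold lower number from compound 3 to compound 4 (2.45 log units; beyond the scatter) and ethynyl in place of thiophen-3-yl giving an at least 280-fold lower number from compound 2 to compound 4 (2.45 log units; beyond the scatter) and ethynyl in place of thiophen-2-yl giving an at least 280-fold lower number from compound 1 to compound 4 (2.45 log units; beyond the scatter). Each step is a minimum and the steps among the three ring-bearing compounds still cannot be read, since those compounds stay at one limit: the limit of > 20000 nM in this assay, at which 3 of the 4 values shown sit.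

The swap removes an aromatic ring, brings in a triple bond and leaves fewer heavy atoms all at once, and compound 4 alone cannot separate these changes. From the compounds shown here alone, whether a small group without a triple bond, such as methyl or vinyl, would also give a readable number remains open, as does the outcome with a nitrile or a longer chain such as propynyl.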